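Compound 1 and a new group on the sulfonyl sulfur

The compounds below may be only part of what the source reports. "The series", "measured", "known", "first", "only" and "open" are said of these compounds alone.

Measured so far in a physicochemical assay for solubility, read by HPLC; a lower number here means a less soluble compound, a higher number a more soluble compound:
Compound 1 `CN1Cc2cc(-c3ccc(-c4cncc(NS(=O)(=O)c5ccc(F)cc5F)c4)s3)cnc2C1=O` gives 20300 ug/mL
Compound 2 `COc1ncc(-c2ccc(-c3cnc4c(c3)CN(C)C4=O)s2)cc1NS(=O)(=O)c1ccc(F)cc1F` gives 18300 ug/mL
Compound 3 `O=C1NCc2cc(-c3ccc(-c4cncc(NS(=O)(=O)c5ccc(F)cc5F)c4)s3)cnc21` gives 1130 ug/mL

Compound 1 stands at the top of these three numbers, a place it shares with one other compound. Compound 4 `CN1Cc2cc(-c3ccc(-c4cncc(NS(=O)(=O)c5ccccc5C(F)(F)F)c4)s3)cnc2C1=O` carries 2-(trifluoromethyl)phenyl in place of 2,4-difluorophenyl on a sulfonyl sulfur and has not yet been measured. Two measured steps start from compound 1, a 1.1-fold lower number from compound 1 to compound 2 (0.05 log units; within the scatter) and an 18-fold lower number from compound 1 to compound 3 (1.25 log units; beyond the scatter), but neither alters the group on the sulfonyl sulfur. The large one removes a methyl that compound 4 keeps, so it offers no direct guide. Only a modest drop, within the scatter, is therefore expected, and the estimate is a 1.6-fold lower number from compound 1 to compound 4 (0.19 log units; within the scatter) for this change. Compound 4 is expected at 13000 ug/mL, with an estimated range from 4000 ug/mL to 30000 ug/mL for the coming measurement.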

Compound 4, solubility: 4280 ug/mL
The estimate for compound 4 lay 3.0-fold (0.48 log units) above the measured number; the measured number falls inside the stated range.
By their numbers in this assay, from the lowest: compound 3; then compound 4; then compounds 2 and 1 (each within the scatter of the next).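

In this assay the group on the sulfonyl sulfur proves able to move the number: 2-(trifluoromethyl)phenyl in place of 2,4-difluorophenyl gives a 4.7-fold lower number from compound 1 to compound 4 (0.68 log units; beyond the scatter), a step beyond the scatter. Among the compounds shown here, the earlier steps left this group untouched, so this is the first reading at this position. No evidence is available on what lies behind this step.

As far as these compounds go, whether the same change gives a similar step on compound 2 or compound 3 stays open. So does how an amine or a carboxylic acid on the phenyl ring would read here.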